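Chloro for ethyl on the ammonium nitrogen of compound 3

A few compounds are considered here, and "the series" means these few. Any claim that something is new, unique, unknown or untested is made for them only; others in the source may bear on it.

Compound 1, `C[N+](C)(CCCC(=O)[O-])Cc1ccccc1`, in an assay for inhibition of gamma-butyrobetaine dioxygenase (Homo sapiens), read by HPLC, with stated times of 15 min and 30 min (a lower number here means a stronger inhibitor, a higher number a weaker inhibitor), returns only a limit, > 1000000 nM.
Compound 2, `C[N+]1(CCCC(=O)O)CCCC1`, gives 490 nM in this assay.
Compound 3, `CCC[N+](C)(C)CCCC(=O)[O-]`, also returns only a limit in this assay, > 1000000 nM.

Of the three measured compounds, only compound 2 yields a number in this assay. Compound 3 stands at the limit of the assay, and the same holds for compound 1 (the limit of > 1000000 nM in this assay, at which 2 of the 3 values shown sit). Going by the values given here, compound 3 therefore cannot be placed against compound 2 by a counted step, and no step between measured compounds is given here.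

Compound 4, `C[N+](C)(CCl)CCCC(=O)[O-]`, differs from compound 3 in one place: chloro in place of ethyl on a saturated chain carbon bound to an amine nitrogen. Read one bond further out, the propyl group of compound 3 becomes a chloromethyl group in compound 4.

Since the substituent on nitrogen in compound 4 is smaller than the ethyl-extended chain of compound 3, and the limit for compound 3 gives no number to measure from, the expected step is uncertain. Compound 4 is estimated to come nearer to a measurable value, and the step from compound 3 to compound 4 is expected to be an at least 5.0-fold lower number from compound 3 to compound 4 (0.69 log units; beyond the scatter) in this assay. Compound 4 is expected to give about 200000 nM, somewhere between 5000 nM and 3000000 nM.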

Compound 4, half-maximal inhibitory concentration: 268000 nM
Estimate against measurement, compound 4: 1.3-fold (0.13 log units) below, and the stated range covers the measured number.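

In this assay, going by these compounds alone, chloro in place of ethyl on a saturated chain carbon bound to an amine nitrogen gives the first step that can be read in this set: an at least 3.7-fold lower number from compound 3 to compound 4 (0.57 log units; beyond the scatter). Going by these compounds, compound 3 returns only a limit, > 1000000 nM, so the step has a lower bound and its full size stays unknown. Read one bond further out, the chloromethyl group gives a number where the propyl group gave none, which moves one compound off the limit that still marks much of this small set: the limit of > 1000000 nM in this assay, at which 2 of the 4 values shown sit.

The compounds shown leave open whether the step follows from the shorter chain or from the chlorine itself, a question that a plain ethyl or methyl group, or a fluoromethyl or hydroxymethyl group, at this place on the nitrogen would help to separate. Other steps in the set cannot be read, so how the remaining compounds relate to compound 4, and whether this change would hold on another core, also stays unresolved.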